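A Bromine for a Chlorine on a Silent Core

This account rests on a few compounds, and the source may have more. Where it says the series, first, only, none or still open, it means among the compounds named here.

Compound 1 `CCOC(=O)C12C(=O)OCC=C1COC2c1ccccc1` and compound 2 `CCOC(=O)C12C(=O)OCC=C1COC2c1ccc(Cl)cc1` share one core and differ only by a chloro in place of hydrogen on an aromatic carbon. In a functional assay on A549 cells (Homo sapiens) for cytotoxicity, read by MTT assay (a higher number here means a weaker inhibitor, a lower number a stronger inhibitor), compound 1 gives > 1000000 nM, which is a limit of the assay and not a number. In this assay compound 2 likewise gives > 1000000 nM, again a limit. The step that the two limits leave unreadable from compound 1 to compound 2 therefore cannot be read, since both values sit at the limit of > 1000000 nM in this assay, at which 2 of the 2 values shown sit. Compound 3 `CCOC(=O)C12C(=O)OCC=C1COC2c1ccc(Br)cc1` carries the change (bromo in place of chloro on an aromatic carbon). Within the data shown here, the only measured step concerns a different change and is of unreadable size, so no shift beyond the scatter can be expected in this assay in either direction. Compound 3 is therefore expected to remain near the same limit, with an estimated step that the limit leaves unreadable from compound 2 to compound 3. The estimate for compound 3 is 1500000 nM, ranging from 500000 nM to 5000000 nM.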

Compound 3, half-maximal inhibitory concentration: > 1000000 nM
Compound 3 ended at the assay's limit; the forecaster's own chance of this, stated with the estimate: 80%; the middle value lies beyond the limit too.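

Compound 3, like compound 1 and compound 2, stands at a limit and not at a number, so none of the steps among them can be read: the limit of > 1000000 nM in this assay, at which 3 of the 3 values shown sit. The compounds shown leave open whether hydrogen, chloro or bromo on that aromatic carbon makes any difference in this assay at all.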